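Moving the hydroxyl in a serinol-type amide of sphingosine kinase 1

The source may hold more compounds than are shown below. What is called first, only, known or untested is meant among the compounds shown, and "the series" means these compounds.

Measured compounds:
compound 1, `CCCCCCCCc1ccc(NC(=O)C(C)(N)CO)cc1`, > 10000 nM in an assay on isolated protein for inhibition of sphingosine kinase 1 (Homo sapiens), read by mobility shift assay; on this read-out higher numbers stand for weaker inhibition and lower numbers for stronger inhibition;
compound 2, `CCCCCCCCc1ccc(NC(=O)[C@H](CO)NC)cc1`, 2800 nM in this assay.

The value recorded for compound 1 in this assay is a limit of the assay, not a number, as the limit of > 10000 nM in this assay, at which 1 of the 2 values shown sits, makes clear. Compound 2 reaches a measured number, and the step of an at least 3.5-fold lower number from compound 1 to compound 2 (0.55 log units; beyond the scatter) shows that a change at the carbonyl carbon of this core can move the read-out beyond the scatter. Compound 3, `CCCCCCCCc1ccc(NC(=O)[C@@H](N)[C@H](C)O)cc1`, differs from compound 1 in the same place: 1-amino-2-hydroxypropyl in place of 1-amino-1-(hydroxymethyl)ethyl on a carbonyl carbon. Within the data shown here, no measured step covers this exact change, so the step from compound 1 gives only a rough guide to its size. The step from compound 1 to compound 2 suggests that rebuilding this group can help, and a modest gain is therefore expected, an at least 2.0-fold lower number from compound 1 to compound 3 (0.30 log units; that floor lies within the scatter), with much uncertainty. Compound 3 is estimated at 5000 nM in this assay, likely between 1500 nM and 20000 nM.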

Compound 3, half-maximal inhibitory concentration: 1100 nM
Compound 3: the middle estimate sits 4.5-fold (0.66 log units) above what was measured; measured number outside the range, below it.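

In this assay, the same atoms joined differently give an at least 9.0-fold lower number from compound 1 to compound 3 (0.95 log units; beyond the scatter), so this carbonyl position responds to how the amino and hydroxyl groups are arranged, not only to which atoms are present. The change also goes past the earlier gain, with a 2.5-fold lower number from compound 2 to compound 3 (0.41 log units; beyond the scatter), and 1-amino-2-hydroxypropyl gives the strongest inhibition of the three groups on this carbonyl carbon. The first of these sizes is only a floor, since compound 1 stands at a limit of the assay and not at a number: the limit of > 10000 nM in this assay, at which 1 of the 3 values shown sits.

The compounds shown do not separate the part played by the defined stereocentres of 1-amino-2-hydroxypropyl from that of the new arrangement itself. As far as these compounds go, whether a methylamino group on this same arrangement, or a carboxylic acid in place of its hydroxyl, would keep the gain also stays open.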